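The source may hold more compounds than are shown below. What is called first, only, known or untested is meant among the compounds shown, and "the series" means these compounds.

Measured so far in a functional assay on A549 cells (Homo sapiens) for inhibition, read by MTT assay, with a stated time of 48 h; on this read-out lower numbers stand for stronger inhibition and higher numbers for weaker inhibition:

- Compound 1 `Oc1cccc(C(c2c[nH]c3ccc(Br)cc23)c2c[nH]c3ccc(Br)cc23)c1` (8000 nM)
- Compound 2 `Brc1ccc2[nH]cc(C(c3c[nH]c4ccc(Br)cc34)C3CCCCC3)c2c1` (5500 nM)
- Compound 3 `Brc1ccc2[nH]cc(C(c3ccc4ccccc4c3)c3c[nH]c4ccc(Br)cc34)c2c1` (8500 nM)

Compound 3 stands level with the other two, as no gap among the three exceeds the usual scatter of repeat measurements. Compound 4 `O=[N+]([O-])c1ccc(C(c2c[nH]c3ccc(Br)cc23)c2c[nH]c3ccc(Br)cc23)cc1` carries 4-nitrophenyl in place of naphthalen-2-yl on a saturated chain carbon bound to two aromatic carbons. Changing the group at this same place gave a 1.5-fold lower number from compound 1 to compound 2 (0.16 log units; within the scatter) and a 1.1-fold higher number from compound 1 to compound 3 (0.03 log units; within the scatter) and a 1.5-fold higher number from compound 2 to compound 3 (0.19 log units; within the scatter), all small. For the measured compounds named here, no measured compound carries 4-nitrophenyl, so this is an extrapolation. In this assay no step beyond the scatter is expected, and the expected step is a 1.2-fold lower number from compound 3 to compound 4 (0.08 log units; within the scatter). For compound 4 the estimated value is 7000 nM, with an expected range of 3000 nM to 16000 nM.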

Compound 4, half-maximal inhibitory concentration: 5500 nM
The estimate for compound 4 lay 1.3-fold (0.10 log units) above the measured number; measured number inside the range.
By their numbers in this assay, from the lowest: compounds 2, 4, 1 and 3 (each within the scatter of the next).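

In this assay, 4-nitrophenyl also stays within the scatter of every other group at this place: a 1.5-fold lower number from compound 3 to compound 4 (0.19 log units; within the scatter), no change at the digits printed from compound 2 to compound 4 (within the scatter) and a 1.5-fold lower number from compound 1 to compound 4 (0.16 log units; within the scatter). Even replacing the two-ring naphthalen-2-yl with the one-ring 4-nitrophenyl, which brings hydrogen-bond acceptors, produces no step beyond the scatter, so all four groups read level. Nothing at hand explains this flat result. As far as these compounds go, whether an amine, a carboxylic acid or a longer chain at this place would move the number beyond the scatter remains open.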